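Methylsulfonylphenyl Replaces Pyridin-4-yl on the Shared Core

The compounds below may be only part of what the source reports. "The series", "measured", "known", "first", "only" and "open" are said of these compounds alone.

Three measured compounds share one core. Compound 1 `C[C@H](Nc1ncnc2[nH]cnc12)c1nn(-c2cccnc2)c2cc(F)ccc12` gives 8% in a functional assay on Bel-7402 cells (Homo sapiens) for inhibition, read by sulforhodamine B assay, with a stated time of 72 h, tested at 10 uM; a lower number here means less inhibition, a higher number more inhibition at the concentration tested (going by the name of the read-out). Compound 2 `C[C@H](Nc1ncnc2[nH]cnc12)c1nn(-c2ccncc2)c2cc(F)ccc12` gives 16% in this assay, and compound 3 `CC(C)[C@H](Nc1ncnc2[nH]cnc12)c1nn(-c2cccnc2)c2cc(F)ccc12` gives 5%. Compound 2 holds the highest of the three numbers, but compound 1 lies within the usual scatter of it, and only compound 3 lies beyond it. The unmeasured compound 4 `C[C@H](Nc1ncnc2[nH]cnc12)c1nn(-c2cccc(S(C)(=O)=O)c2)c2cc(F)ccc12` differs from compound 2 in one place: 3-(methylsulfonyl)phenyl in place of pyridin-4-yl on an aromatic nitrogen. Going by the values given here, only one measured step changes the group on the same aromatic nitrogen: a number 8 percentage points higher from compound 1 to compound 2 (within the scatter). The other step, a number 3 percentage points lower from compound 1 to compound 3 (within the scatter), alters the saturated chain carbon instead and bears less on this change. Neither step leaves the scatter, so no step beyond the scatter is expected in this assay in either direction. The expected step is a number 2 percentage points lower from compound 2 to compound 4 (within the scatter). Compound 4 is therefore estimated at 14%, with a range from 2% to 30%.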

Compound 4, a percentage reported as inhibition, at one concentration (the size of the read-out at that concentration, not a potency): -16%
Compound 4: middle estimate off by 30 percentage points, on the high side; the measured number lies below the stated range.
By their numbers in this assay, from the lowest: compound 4; then compounds 3, 1 and 2 (each within the scatter of the next, the first and the last beyond it).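

At this aromatic nitrogen, the swap between the two pyridinyl groups stayed within the scatter, but 3-(methylsulfonyl)phenyl moves the number beyond it in this assay, in both available comparisons (a number 32 percentage points lower from compound 2 to compound 4 (beyond the scatter); a number 24 percentage points lower from compound 1 to compound 4 (beyond the scatter)). The position is therefore not indifferent to its group in this read-out, although this change replaces a ring with one hetero atom by a ring of carbon only and adds the methylsulfonyl group, so the step cannot be divided between those two parts. Nothing available explains the drop.

The compounds shown leave open whether plain phenyl would behave like the pyridinyl groups or like 3-(methylsulfonyl)phenyl, and how a phenyl bearing an amine or a carboxylic acid would read. They also leave open whether the same change would give a similar step with isopropyl in place of methyl on the saturated chain carbon.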